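A few compounds are considered here, and "the series" means these few. Any claim that something is new, unique, unknown or untested is made for them only; others in the source may bear on it.

Measured so far in an assay on CHO cells for displacement of a labelled ligand from adenosine receptor A3 (Homo sapiens), read by scintillation counting, tested at 10 uM; on this read-out lower numbers stand for less inhibition and higher numbers for more inhibition at the one concentration tested (going by the name of the read-out):
compound 1 `CC(C)(C)Cc1c(Br)sc(N)c1C(=O)c1cccc(Cl)c1` gives 1%
compound 2 `CC(C)(C)Cc1c(Br)sc(N)c1C(=O)c1cccc(C(F)(F)F)c1` gives 4%
compound 3 `CC(C)(C)Cc1c(-c2ccccc2)sc(N)c1C(=O)c1cccc(Cl)c1` gives 5%

All three numbers in this assay lie within the usual scatter of one another, so none stands apart. Between compound 1 and compound 2 the change is trifluoromethyl in place of chloro on an aromatic carbon; it made a number 3 percentage points higher from compound 1 to compound 2 (within the scatter). The core of compound 3 differs from the core of compound 1 by phenyl in place of bromo on an aromatic carbon, a step of a number 4 percentage points higher from compound 1 to compound 3 (within the scatter).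

Compound 4 `CC(C)(C)Cc1c(-c2ccccc2)sc(N)c1C(=O)c1cccc(C(F)(F)F)c1` is not yet measured. It differs from compound 3 by trifluoromethyl in place of chloro on an aromatic carbon, the same change as from compound 1 to compound 2, at a place described in identical words. For compound 4 the expected step is a number 2 percentage points higher from compound 3 to compound 4 (within the scatter). Within the data shown here, this rests on the earlier step of a number 3 percentage points higher from compound 1 to compound 2 (within the scatter) and on compound 3 at 5%, with only three compounds behind it. Compound 4 is estimated at 7%, with a range for compound 4 from -4% to 18%.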

Compound 4, a percentage reported as inhibition, at one concentration (the size of the read-out at that concentration, not a potency): 1%
Beside the measured number, compound 4's estimate is 6 percentage points above it; the measured number falls inside the stated range.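

In this assay, trifluoromethyl in place of chloro gives a number 4 percentage points lower from compound 3 to compound 4 (within the scatter), and the two cores do not separate for this change: the same change on two cores in this assay, a number 3 percentage points higher (within the scatter) from compound 1 to compound 2 and a number 4 percentage points lower (within the scatter) from compound 3 to compound 4, 7 percentage points apart, within the scatter of two such steps. Phenyl in place of bromo gives a number 3 percentage points lower from compound 2 to compound 4 (within the scatter), and the two cores do not separate for this change either: the same change on two cores in this assay, a number 4 percentage points higher (within the scatter) from compound 1 to compound 3 and a number 3 percentage points lower (within the scatter) from compound 2 to compound 4, 7 percentage points apart, within the scatter of two such steps. Among these compounds, this shows only that neither change moves the read-out beyond the scatter on either core; it does not show that either change carries a real effect of a given size or direction from one core to another.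

As far as these compounds go, whether an amine or a carboxylic acid in place of chloro, or a longer chain in place of phenyl, would give a number beyond the scatter stays open. Potency also stays open, as the read-out comes from one concentration.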